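A few compounds are considered here, and "the series" means these few. Any claim that something is new, unique, unknown or untested is made for them only; others in the source may bear on it.

Compound 1 `COC/C1=C/C[C@](C)(CCC=C(C)C)/C=C/[C@@H](OC(=O)C=C(C)C)[C@](C)(O)/C=C/C1=O` carries a methoxy group on a side chain of the shared core. In a functional assay on MCF7 cells (Homo sapiens) for antiproliferative activity, read by MTT assay, with a stated time of 48 h (a higher number here means a weaker inhibitor, a lower number a stronger inhibitor), compound 1 gives 4130 nM, and compound 2 `COCOC/C1=C/C[C@](C)(CCC=C(C)C)/C=C/[C@@H](OC(=O)C=C(C)C)[C@](C)(O)/C=C/C1=O` gives 3120 nM; the two numbers lie within the usual scatter of each other, as a 1.3-fold lower number from compound 1 to compound 2 (0.12 log units; within the scatter) shows. Compound 3 `CC(C)=CCC[C@]1(C)/C=C/[C@@H](OC(=O)C=C(C)C)[C@](C)(O)/C=C/C(=O)/C(Cn2cc(CO)nn2)=C\C1` differs from compound 1 thus: 4-(hydroxymethyl)-1H-1,2,3-triazol-1-yl in place of methoxy on a saturated chain carbon bound to a double-bonded ring carbon. Among the compounds with values here, the single measured step changes the same region only slightly and stayed within the scatter, so it offers little guidance for bringing in a five-membered aromatic ring. The step of a 1.1-fold lower number from compound 1 to compound 3 (0.06 log units; within the scatter) is expected to stay within the scatter. Compound 3 is estimated at 3600 nM, between 1200 nM and 11000 nM.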

Compound 3, half-maximal inhibitory concentration: 2930 nM
Estimate against measurement, compound 3: 1.2-fold (0.09 log units) above; measured number inside the range.
By their numbers in this assay, from the lowest: compounds 3, 2 and 1 (each within the scatter of the next).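

In this assay, the saturated chain carbon bound to a double-bonded ring carbon accepts a far larger group than methoxy, 4-(hydroxymethyl)-1H-1,2,3-triazol-1-yl, with a 1.4-fold lower number from compound 1 to compound 3 (0.15 log units; within the scatter) and with a 1.1-fold lower number from compound 2 to compound 3 (0.03 log units; within the scatter). The earlier step changed only a small chain, whereas these two bring in a five-membered aromatic ring and a hydrogen-bond donor, and the number still does not move beyond the scatter. Nothing measured here explains this. Still open, on these data alone, is whether an amine or a carboxylic acid in place of the hydroxymethyl would shift the number. A longer chain linking the ring to the shared core also remains untested in the compounds shown.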